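Compound 3 and a change at one stereocentre

The source may hold more compounds than are shown below. What is called first, only, known or untested is meant among the compounds shown, and "the series" means these compounds.

Values so far in an ADME assay on Caco-2 cells (Homo sapiens) for permeability, tested at 50 uM (a lower number here means that the compound crosses the layer more slowly, a higher number that the compound crosses the layer faster), are:
- compound 1 `COc1cc(C)c(S(=O)(=O)N(C)CCOCC(=O)N2CCC(C(C)(C)CN(C)C)CC2)c(C)c1` gives 13.6 10^-6 cm/s
- compound 2 `COc1cc(C)c(S(=O)(=O)N(C)CCOCC(=O)N2CCN(C3CCN(C4CC4)CC3)CC2)c(C)c1` gives 11.8 10^-6 cm/s
- compound 3 `COc1cc(C)c(S(=O)(=O)N(C)CCOCC(=O)N2CCN([C@@H]3CN4CCC3CC4)CC2)c(C)c1` gives 1.4 10^-6 cm/s

Compound 3 has the lowest number of the three, and the numbers of compound 1 and compound 2 both lie beyond the scatter above it. The next compound to be measured is compound 4 `COc1cc(C)c(S(=O)(=O)N(C)CCOCC(=O)N2CCN([C@H]3CN4CCC3CC4)CC2)c(C)c1` and it differs from compound 3 in one way only: the two compounds have the same atoms and bonds; at least one stereo element is drawn with a configuration in one of them and without one in the other: 1 of 3 stereo elements differ; a stereocentre at a saturated ring carbon is drawn S in compound 3 and R in compound 4. In other words, the two compounds have the same atoms and bonds, but a stereocentre at a saturated ring carbon is drawn S in compound 3 and R in compound 4.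

Among the measured compounds shown here, only one measured step touches this part of the molecule: an 8.4-fold lower number from compound 2 to compound 3 (0.93 log units; beyond the scatter). That step replaces a whole group on an amine nitrogen in a ring, while here no atom leaves or enters. For the measured compounds named here, it therefore gives no direct measure of a change in configuration, and no measured pair in this set differs in that way alone. Going by these compounds, the expected result in this assay is a 1.1-fold higher number from compound 3 to compound 4 (0.03 log units; within the scatter) and no step beyond the scatter is anticipated, though this remains untested. The estimated value for compound 4 is 1.5 10^-6 cm/s with an expected range (0.7 10^-6 cm/s to 3.5 10^-6 cm/s).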

Compound 4, apparent permeability: 1.9 10^-6 cm/s
For compound 4 the middle estimate is 1.3-fold (0.10 log units) below the measured one; the measured number falls inside the stated range.
By their numbers in this assay, from the lowest: compounds 3 and 4 (each within the scatter of the next); then compounds 2 and 1 (each within the scatter of the next).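

Among the compounds shown here, compounds 3 and 4 give the first direct look at the configuration of this saturated ring carbon. In this assay, drawing the stereocentre R rather than S gives a 1.4-fold higher number from compound 3 to compound 4 (0.13 log units; within the scatter), so no effect of this change can be read from the pair. Replacing the group of 9 heavy atoms with the group of 8 heavy atoms still gives a 6.2-fold lower number from compound 2 to compound 4 (0.79 log units; beyond the scatter), which shows that the fall seen earlier with compound 3 is not confined to one drawn configuration, although one caution applies to treating compounds 3 and 4 as a clean comparison of two configurations: the fact that one of compounds 3 and 4 is drawn with a defined configuration and the other without, at the place where they differ.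

Going by these compounds, it remains open whether this stereocentre would still make no readable difference if a further group, such as a hydroxyl or a fluorine, were attached to the group of 8 heavy atoms. It is also unresolved which part of the exchange between the two larger groups, whether the three-membered carbon ring or the second six-membered ring, accounts for the step from compound 2.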